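Moving a Methyl Group: One Change, Two Cores

This account rests on a few compounds, and the source may have more. Where it says the series, first, only, none or still open, it means among the compounds named here.

In a functional assay on OVCAR-3 cells (Homo sapiens) for antiproliferative activity, read by MTT assay, with a stated time of 24 h (on this read-out higher numbers stand for weaker inhibition and lower numbers for stronger inhibition), compound 1 `Cc1ccccc1-n1cc(-c2ccccc2NS(=O)(=O)c2c[nH]c(=O)[nH]c2=O)nn1` gives 6550 nM. Compound 2 `Cc1cccc(-n2cc(-c3ccccc3NS(=O)(=O)c3c[nH]c(=O)[nH]c3=O)nn2)c1` differs from it only by 3-methylphenyl in place of 2-methylphenyl on an aromatic nitrogen and in this assay compound 2 gives 3150 nM, so the change made a 2.1-fold lower number from compound 1 to compound 2 (0.32 log units; beyond the scatter). Compound 3 `Cc1ccccc1-n1cc(-c2cccc(NS(=O)(=O)c3c[nH]c(=O)[nH]c3=O)c2)nn1` stands on a second core; the difference between the two cores is not broken down here. In this assay compound 3 gives 6230 nM, a number close to that of compound 1, and the number for compound 2 also lies within the usual scatter of it. Compound 4 `Cc1cccc(-n2cc(-c3cccc(NS(=O)(=O)c4c[nH]c(=O)[nH]c4=O)c3)nn2)c1` carries the same change, (3-methylphenyl in place of 2-methylphenyl on an aromatic nitrogen), at the same place. For the measured compounds named here, the expected step is a 2.0-fold lower number from compound 3 to compound 4 (0.30 log units; within the scatter) because the single earlier example gave a 2.1-fold lower number from compound 1 to compound 2 (0.32 log units; beyond the scatter) and nothing else here speaks for or against carrying it over. Compound 4 is estimated at 3100 nM, with a range from 1500 nM to 6500 nM.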

Compound 4, half-maximal inhibitory concentration: 4080 nM
For compound 4 the middle estimate is 1.3-fold (0.12 log units) below the measured one, within the range that was stated.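

In this assay, replacing 2-methylphenyl with 3-methylphenyl gives a 1.5-fold lower number from compound 3 to compound 4 (0.18 log units; within the scatter), so on this core the step alone cannot be told from the usual variation between repeated measurements. Set beside the step on the first core, it points the same way and the two do not differ measurably: the same change on two cores in this assay, a 2.1-fold lower number (0.32 log units; beyond the scatter) from compound 1 to compound 2 and a 1.5-fold lower number (0.18 log units; within the scatter) from compound 3 to compound 4, 1.4-fold (0.13 log units) apart, within the scatter of two such steps. This agrees with the change carrying over between these two cores, but two pairs are a thin basis, and they neither establish a general rule for the series nor explain why the numbers move.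

The compounds shown carry only a methyl group on this phenyl ring. From the compounds shown here alone, whether 4-methylphenyl, a methoxy group, a chlorine atom or a longer chain such as ethyl would behave alike remains open, as does the behaviour of the change on a third core.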